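The source may report more compounds than this note shows. Statements on the series, on what has been measured and on what is new or still open speak of the compounds shown alone.

Measured in an ADME assay on NIH3T3 cells (Mus musculus) for cytotoxicity; a higher number here means that more compound is tolerated, a lower number that less compound is tolerated:
- Compound 1 `CC(C)(C)CC#Cc1cc2ncnc(Nc3ccc(OCc4cccc(F)c4)c(Cl)c3)c2s1`: > 50 uM (a limit, not a number)
- Compound 2 `CCCN(CC#Cc1cc2ncnc(Nc3ccc(OCc4cccc(F)c4)c(Cl)c3)c2s1)CCC`: > 50 uM (a limit, not a number)
- Compound 3 `CN(C)CC#Cc1cc2ncnc(Nc3ccc(OCc4cccc(F)c4)c(Cl)c3)c2s1`: > 50 uM (a limit, not a number)

Compound 3 has no number in this assay, only the limit > 50 uM. The series offers the same picture throughout: the limit of > 50 uM in this assay, at which 3 of the 3 values shown sit.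

Compound 4 `COCC#Cc1cc2ncnc(Nc3ccc(OCc4cccc(F)c4)c(Cl)c3)c2s1` carries methoxy in place of dimethylamino on a saturated chain carbon bound to a triple-bonded carbon.

The nearest measured changes are at that same place, and neither has a readable size: a step that the two limits leave unreadable from compound 1 to compound 3, and a step that the two limits leave unreadable from compound 2 to compound 3. The same holds for a step that the two limits leave unreadable from compound 1 to compound 2. These steps give no direction, so no shift beyond the scatter is expected. The expected step is a step that the limit leaves unreadable from compound 3 to compound 4. Compound 4 is estimated at 60 uM, with an expected range of 30 uM to 100 uM.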

Compound 4, half-maximal toxic concentration: > 50 uM
Compound 4: no number, only a limit; the forecaster's own chance of this, stated with the estimate: 85%; the middle value lies beyond the limit too.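

In this assay compound 4 gives > 50 uM, a limit and not a number. Among the compounds shown here, no step from compound 1, compound 2 or compound 3 to compound 4 can be read. The compounds shown leave open whether the group on the saturated chain carbon changes tolerance at all: the limit of > 50 uM in this assay, at which 4 of the 4 values shown sit.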